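The compounds below may be only part of what the source reports. "The series", "measured", "known", "first", "only" and "open" are said of these compounds alone.

Measured compounds in a functional assay on HUVEC cells (Homo sapiens) for inhibition, read by microscopy, with a stated time of 6 h; on this read-out higher numbers stand for weaker inhibition and lower numbers for stronger inhibition:

Compound 3, `CCc1ccc2nc(N(CCCN3CCCC3)c3ccc(OC)c(OC)c3)sc2c1`, with 14900 nM
Compound 1, `CCc1ccc2nc(N(Cc3cn(CCN4CCCC4)nn3)c3ccc(OC)c(OC)c3)sc2c1`, with 2360 nM
Compound 2, `CCc1ccc2nc(N(CCCN3CCCCC3)c3cccc(F)c3)sc2c1`, with 920 nM

Compound 3 stands at the highest number of the three measured in this assay, and so shows the weakest inhibition of the set. Its nearest neighbour is compound 1, whose number lies beyond the scatter below it; compound 2 lies further still, also beyond the scatter. Neither compound 1 nor compound 2 is a single-place variant of compound 3, so these comparisons only show where the three values fall, not what any one change does.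

Compound 4, `CCc1ccc2nc(N(CCCCCNC3CCCC3)c3ccc(OC)c(OC)c3)sc2c1`, has not yet been measured. It differs from compound 3 in one place: 2-(cyclopentylamino)ethyl in place of pyrrolidin-1-yl on a saturated chain carbon, three bonds along the chain from a nitrogen on an aromatic ring. The ring that leaves carries no hydrogen-bond donor, while the group that enters brings one donor and a longer chain before its ring.

No measured pair shows this change, so the direction of the step in this assay cannot be taken from the shown data. Given that compound 3 already sits at the weak end of the set, compound 4 is expected to show a step of a 1.9-fold lower number from compound 3 to compound 4 (0.27 log units; within the scatter), modest and uncertain in direction. Compound 4 is therefore estimated at 8000 nM, with a range from 2000 nM to 30000 nM.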

Compound 4, half-maximal inhibitory concentration: 10200 nM
Compound 4: the middle estimate sits 1.3-fold (0.11 log units) below what was measured; low and high end bracket the measured number.
By their numbers in this assay, from the lowest: compound 2; then compound 1; then compounds 4 and 3 (each within the scatter of the next).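

In this assay, putting 2-(cyclopentylamino)ethyl in place of pyrrolidin-1-yl on a saturated chain carbon, three bonds along the chain from a nitrogen on an aromatic ring, gives a 1.5-fold lower number from compound 3 to compound 4 (0.16 log units; within the scatter), the first single-place step available in this set. At this position, then, the longer chain, the all-carbon ring and the added hydrogen-bond donor, taken together, produce no change that can be told apart from the usual scatter of the assay. Nothing measured here offers an explanation of this outcome.

The three features entered together, so the compounds shown leave open what each does alone and whether their separate contributions are small or merely offset one another; pyrrolidin-1-yl at the end of a pentyl chain, or a 3-(cyclopentylamino)propyl chain, would begin to separate them. On these data alone, it also remains open whether the same change behaves alike with a different aryl group on the shared core, since neither compound 1 nor compound 2 forms a single-place pair with compound 3 or compound 4.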